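Removing the vinyl group from compound 1

The source may hold more compounds than are shown below. What is called first, only, known or untested is meant among the compounds shown, and "the series" means these compounds.

Among the measured compounds shown here, in a functional assay on NCI-H522 cells (Homo sapiens) for cytotoxicity, with a stated time of 3 days (on this read-out lower numbers stand for stronger inhibition and higher numbers for weaker inhibition), compound 1 `C=Cc1nc2ccccc2[se]1` gives 12200 nM, which is the only actual number in this small set. Compound 2 `C=Cc1sc(-c2ccc(F)cc2)nc1C(=O)OCC` is recorded only as a limit, > 40000 nM. The next structure, compound 3 `c1ccc2[se]cnc2c1`, keeps the core of compound 1 and differs in one place: hydrogen in place of vinyl on an aromatic carbon. This puts hydrogen in place of vinyl on an aromatic carbon, next to the ring nitrogen and next to the ring selenium. For the measured compounds named here, no measured pair of compounds shows what such a change does in this assay, so any forecast is uncertain. A moderate shift towards weaker inhibition is expected, and a result that also reaches a limit would not be surprising. The expected change is a 2.0-fold higher number from compound 1 to compound 3 (0.31 log units; beyond the scatter). For compound 3 the estimated value is 25000 nM, with an expected range from 10000 nM to 60000 nM.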

Compound 3, half-maximal inhibitory concentration: > 40000 nM
Compound 3 gave a limit, no number (the forecaster's own chance of this, stated with the estimate: 35%); at least 1.6-fold (0.20 log units) between middle value and limit.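

Compound 3 is recorded in this assay only as a limit, > 40000 nM, not as a number. Hydrogen in place of vinyl on this aromatic carbon, next to the ring nitrogen and next to the ring selenium, thus gives the first step that can be read at this position, an at least 3.2-fold higher number from compound 1 to compound 3 (0.51 log units; beyond the scatter), and on the shared core only the compound carrying the vinyl group keeps an actual number. The step is only a minimum, and its true size stays unknown, because compound 3 sits at a limit: the limit of > 40000 nM in this assay, at which 2 of the 3 values shown sit.

From the compounds shown here alone, whether an ethyl group, a longer chain or an amine on this aromatic carbon would give an actual number in this assay stays open. Nor do the compounds shown tell whether compound 1 owes its 12200 nM to the double bond of the vinyl group or to any carbon group at this place.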